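The source may hold more compounds than are shown below. What is called first, only, known or untested is meant among the compounds shown, and "the series" means these compounds.

Measured compounds in a functional assay on THP-1 cells (Homo sapiens) for cytotoxicity, read by MTT assay, with a stated time of 24 h; on this read-out higher numbers stand for weaker inhibition and lower numbers for stronger inhibition:
compound 1 `CCCCn1cc(Cn2nc(N)c3c(C(F)(F)F)cc(-c4ccccc4)nc32)nn1` gives 46.1 ug/mL
compound 2 `Cc1ccc(-n2cc(Cn3nc(N)c4c(C(F)(F)F)cc(-c5ccccc5)nc43)nn2)cc1` gives 98.6 ug/mL
compound 3 `COc1ccc(NC(=O)Cn2cc(Cn3nc(N)c4c(C(F)(F)F)cc(-c5ccccc5)nc43)nn2)cc1` gives 56.7 ug/mL

Compound 3 holds the second highest of the three numbers; its nearest neighbour is compound 1, with a 1.2-fold higher number from compound 1 to compound 3 (0.09 log units; within the scatter), and its furthest is compound 2, with a 1.7-fold lower number from compound 2 to compound 3 (0.24 log units; within the scatter). Among the measured compounds shown here, only one of the three steps, a 2.1-fold higher number from compound 1 to compound 2 (0.33 log units; beyond the scatter), reaches beyond the scatter, and all three concern the group on the aromatic nitrogen of the shared core, not the amide end that compound 3 alone carries.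

Compound 4 `Nc1nn(Cc2cn(CC(=O)Nc3c(F)cccc3F)nn2)c2nc(-c3ccccc3)cc(C(F)(F)F)c12` differs from compound 3 as follows: 2,6-difluorophenyl in place of 4-methoxyphenyl on an amide-type nitrogen. For the measured compounds named here, no measured pair changes the aryl group on the amide-type nitrogen, so there is no direct precedent. Going by the values given here, the whole series so far sits within a narrow band in this assay, and the change leaves the rest of compound 3 untouched, so the expectation for compound 4 is no step beyond the scatter, a 1.0-fold higher number from compound 3 to compound 4 (0.00 log units; within the scatter). Compound 4 is therefore estimated at 57 ug/mL, with a range from 30 ug/mL to 110 ug/mL.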

Compound 4, half-maximal inhibitory concentration: 43.3 ug/mL
For compound 4 the middle estimate is 1.3-fold (0.12 log units) above the measured one, and the stated range covers the measured number.
By their numbers in this assay, from the lowest: compounds 4, 1, 3 and 2 (each within the scatter of the next, the first and the last beyond it).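

In this assay, among the compounds shown here, the first change of the aryl group on the amide-type nitrogen, 2,6-difluorophenyl in place of 4-methoxyphenyl, gives a 1.3-fold lower number from compound 3 to compound 4 (0.12 log units; within the scatter) and so cannot be told from the scatter. Exchanging the whole group on the aromatic nitrogen gives a 2.3-fold lower number from compound 2 to compound 4 (0.36 log units; beyond the scatter) when compared with 4-methylphenyl, a step that the 4-methoxyphenyl amide did not show beyond the scatter, but a 1.1-fold lower number from compound 1 to compound 4 (0.03 log units; within the scatter) when compared with butyl. Nothing measured here bears on why these steps have the size they do.

The two amides change the methoxy group and the two fluorines together, so the contribution of each cannot be separated. Open, from the compounds shown here alone, is whether an unsubstituted phenyl or a 4-fluorophenyl on the amide-type nitrogen stays in this band, and whether a carboxylic acid replacing the whole amide moves the number.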